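A few compounds are considered here, and "the series" means these few. Any claim that something is new, unique, unknown or untested is made for them only; others in the source may bear on it.

Measured in a functional assay for inhibition, with Sus scrofa as the target; a lower number here means a stronger inhibitor, a higher number a weaker inhibitor:
- Compound 1 `CC1(C)Oc2ccc(C#N)cc2[C@@H](On2ccccc2=O)[C@]1(C)O`: > 100000 nM
- Compound 2 `CC1(C)Oc2ccc(C#N)cc2[C@@H](Oc2ccc(=O)[nH]n2)[C@]1(C)O`: 6 nM

Among the measured compounds shown here, compound 2 carries the only actual number here, while the entry for compound 1 is a limit of the assay. For the measured compounds named here, that limit, (the limit of > 100000 nM in this assay, at which 1 of the 2 values shown sits), also means that the size of the one measured step is itself a bound. That step is an at least 16000-fold lower number from compound 1 to compound 2 (4.22 log units; beyond the scatter), and it exchanges one whole ring group on the oxygen for another.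

Compound 3 `Cn1nc(O[C@@H]2c3cc(C#N)ccc3OC(C)(C)[C@@]2(C)O)ccc1=O` keeps everything in compound 2 except for one small edit: methyl in place of hydrogen on an aromatic nitrogen. The measured step, an at least 16000-fold lower number from compound 1 to compound 2 (4.22 log units; beyond the scatter), shows that this assay can respond very sharply to the group on that oxygen. However, it replaced a whole ring group, so it does not measure what a single methyl does. A much smaller shift is therefore expected, probably towards a weaker inhibitor, though the direction remains uncertain. The expected step is a 5.0-fold higher number from compound 2 to compound 3 (0.70 log units; beyond the scatter). The estimated value for compound 3 is 30 nM, with an expected range from 4 nM to 400 nM.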

Compound 3, half-maximal inhibitory concentration: 30 nM
Compound 3: the middle estimate sits on the measured number at the digits printed, and the stated range covers the measured number.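

In this assay, methyl in place of hydrogen on the aromatic nitrogen gives a 5.0-fold higher number from compound 2 to compound 3 (0.70 log units; beyond the scatter), a modest but real weakening, and inhibition remains strong, so strong inhibition here does not require that hydrogen. The gain over the group on the oxygen in compound 1 also survives this edit, as the second comparison shows: an at least 3300-fold lower number from compound 1 to compound 3 (3.52 log units; beyond the scatter). Compound 1 stands at a limit of the assay, so this second comparison gives only a bound on the size of the gap: the limit of > 100000 nM in this assay, at which 1 of the 3 values shown sits.

On these data alone, whether ethyl, a longer chain or a chain ending in an amine on that nitrogen would behave like methyl remains open, and so does how far the weakening would grow with the size of the group. The compounds shown also cannot separate the effect of losing the hydrogen from that of adding the carbon, as this single edit does both at once, so the reason for the modest weakening remains unknown.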